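The source may hold more compounds than are shown below. What is called first, only, known or untested is meant among the compounds shown, and "the series" means these compounds.

Measured compounds in a functional assay on Jurkat cells (Homo sapiens) for activation, with a stated time of 24 h; a lower number here means that less compound is needed, a higher number that more compound is needed for the effect:
- compound 1 `Oc1ccccc1CNc1ccc(-c2ccc(Cl)cc2)cc1`: 2390 nM
- compound 2 `Cc1ccc(-c2ccc(NCc3ccccc3O)cc2)cc1`: 3790 nM

Compound 2 gives the highest of the two numbers in this assay, and its nearest neighbour is compound 1, which sits a 1.6-fold higher number from compound 1 to compound 2 (0.20 log units; within the scatter); the two compounds are therefore not separated beyond the scatter. Among the measured compounds shown here, the only step so far is that from chloro to methyl, and it left the number essentially in place.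

Compound 3 `Oc1ccccc1CNc1ccc(-c2ccc(-c3ccccc3)cc2)cc1` has not yet been measured in this assay. It differs from compound 2 by phenyl in place of methyl on an aromatic carbon. For the measured compounds named here, the one measured step bears on it only loosely: it swaps one small group for another at the same aromatic carbon, whereas here a much larger group enters, and nothing shows what a phenyl at that position does. In the absence of a step of comparable kind, no direction beyond the scatter can be argued from the data; the expected step of a 1.2-fold higher number from compound 2 to compound 3 (0.07 log units; within the scatter) is small, with the uncertainty widened to cover either direction. The estimate for compound 3 in this assay is 4500 nM, in a range from 1500 nM to 14000 nM.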

Compound 3, half-maximal effective concentration: "not active" (no number reported)
Compound 3 has no reported number here; no gap can be computed for the estimate.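

In this assay, among the compounds shown here, compound 3 is reported as not active, without a number, so no step from compound 2 to compound 3 can be read. Nothing at hand bears on the reason for this result. The compounds shown leave open whether a group at that aromatic carbon, larger than methyl but smaller than phenyl, would keep a measurable number.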